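A few compounds are considered here, and "the series" means these few. Any claim that something is new, unique, unknown or untested is made for them only; others in the source may bear on it.

Measured in a functional assay on MDA-MB-231 cells (Homo sapiens) for antiproliferative activity, read by MTT assay, with a stated time of 72 h; a higher number here means a weaker inhibitor, a lower number a stronger inhibitor:

- compound 1 `O=C(CCc1cccc2c1B(O)OC2)Nc1ccc(F)cc1` gives 440 nM
- compound 2 `O=C(CCc1cccc2c1B(O)OC2)Nc1ccccc1-c1ccccc1` gives 18000 nM
- compound 3 `CC(=O)c1ccc(-c2cccc(NC(=O)CCc3ccccc3)c2)cc1` gives 2700 nM

At 2700 nM, compound 3 holds the middle place among the three. Compound 1 has the lower number and compound 2 the higher, and compound 3 differs from each by more than the scatter.

The next compound is compound 4 `CC(=O)c1ccc(-c2cccc(NC(=O)CCc3cccc4c3C(O)OC4)c2)cc1`, made from compound 3 by one structural change: a group of 10 heavy atoms (8 carbon, 2 oxygen; one five-membered non-aromatic ring with 1 hetero atom, one six-membered aromatic ring of carbon only) in place of a group of 6 heavy atoms (6 carbon; one six-membered aromatic ring of carbon only), on a saturated chain carbon, two bonds along the chain from a carbonyl carbon. The phenyl group on the saturated chain carbon gives way to the larger group, while the rest of the molecule stays the same.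

Within the data shown here, no pair of measured compounds differs in only one place, so nothing shows directly what this change does in this assay. With no evidence for a direction, only a small step is expected, one that stays within the scatter. The expected change is a 1.4-fold lower number from compound 3 to compound 4 (0.13 log units; within the scatter). For compound 4 the estimated value is 2000 nM, with an expected range from 500 nM to 8000 nM.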

Compound 4, half-maximal inhibitory concentration: 29000 nM
Beside the measured number, compound 4's estimate is 15-fold (1.16 log units) below it; measured number outside the range, above it.
By their numbers in this assay, from the lowest: compound 1; then compound 3; then compounds 2 and 4 (each within the scatter of the next).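

On the saturated chain carbon, two bonds along the chain from a carbonyl carbon, replacing phenyl with the larger group is far from neutral: in this assay it gives an 11-fold higher number from compound 3 to compound 4 (1.03 log units; beyond the scatter) and this step lies beyond the scatter. Among these compounds, this is the first pair here that differs in one place, and it shows that the number responds strongly to what sits at this position, although the added ring, the hydrogen-bond donor and the hydrogen-bond acceptors all enter together. Nothing measured here speaks to what lies behind this rise.

With one step at this position, the compounds shown do not separate the five-membered non-aromatic ring from the other parts of the change. They also leave open what a methyl or a longer chain ending in phenyl would do at this place.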